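Swapping the terminal aromatic group of compound 2

The source may hold more compounds than are shown below. What is called first, only, known or untested is meant among the compounds shown, and "the series" means these compounds.

In a functional assay on SK-OV-3 cells (Homo sapiens) for cytotoxicity (a lower number here means a stronger inhibitor, a higher number a weaker inhibitor), compound 2 `C=C/C=C\[C@H](C)[C@H](OC(N)=O)[C@@H](C)[C@H](O)[C@@H](C)C/C(C)=C\[C@H](C)[C@@H](O)[C@@H](C)/C=C\CCc1cc(F)cc(F)c1` gives 360 nM, within the scatter of compound 1 `C=C/C=C\[C@H](C)[C@H](OC(N)=O)[C@@H](C)[C@H](O)[C@@H](C)C/C(C)=C\[C@H](C)[C@@H](O)[C@@H](C)/C=C\CCc1ccc(C)c(O)c1` at 410 nM. Compound 3 `C=C/C=C\[C@H](C)[C@H](OC(N)=O)[C@@H](C)[C@H](O)[C@@H](C)C/C(C)=C\[C@H](C)[C@@H](O)[C@@H](C)/C=C\CCc1sccc1C` differs from compound 2 as follows: 3-methylthiophen-2-yl in place of 3,5-difluorophenyl on a saturated chain carbon, two bonds along the chain from a double-bonded chain carbon. Among the measured compounds shown here, only one measured step bears on this place, a 1.1-fold lower number from compound 1 to compound 2 (0.06 log units; within the scatter), and it stays within the scatter. No thiophene at this place has been measured yet, so that step is only indirect guidance. The expected change is a 1.1-fold higher number from compound 2 to compound 3 (0.05 log units; within the scatter), with no step beyond the scatter anticipated. For compound 3 the estimated value is 400 nM, with an expected range of 150 nM to 1000 nM.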

Compound 3, half-maximal inhibitory concentration: 370 nM
Beside the measured number, compound 3's estimate is 1.1-fold (0.03 log units) above it; the measured number falls inside the stated range.
By their numbers in this assay, from the lowest: compounds 2, 3 and 1 (each within the scatter of the next).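

In this assay, a five-membered aromatic ring with a sulfur hetero atom now joins the six-membered rings at this place: 3-methylthiophen-2-yl in place of 3,5-difluorophenyl gives a 1.0-fold higher number from compound 2 to compound 3 (0.01 log units; within the scatter), and in place of 3-hydroxy-4-methylphenyl it gives a 1.1-fold lower number from compound 1 to compound 3 (0.04 log units; within the scatter). All three terminal aromatic groups thus stand within the scatter of one another. Nothing at hand accounts for this flat response.

Every terminal group shown is aromatic, so an amine, a carboxylic acid or a cyclohexyl group at this place remains open. Going by these compounds, a longer chain before the ring also remains open.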